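This account rests on a few compounds, and the source may have more. Where it says the series, first, only, none or still open, it means among the compounds named here.

Working notes on the series. Compound 1 `CC(C)N(C)c1ccc2cc(NC(=O)CCc3ccc(C(F)(F)F)cc3)ccc2n1` gives 2 nM in an assay on isolated protein for displacement of a labelled ligand from melanin-concentrating hormone receptor 1 (Homo sapiens) (a higher number here means a weaker inhibitor, a lower number a stronger inhibitor), and compound 2 `CN(c1ccc2cc(NC(=O)CCc3ccc(C(F)(F)F)cc3)ccc2n1)C1CCCC1` gives 2 nM; the step of no change at the digits printed from compound 1 to compound 2 (within the scatter) lies within the scatter. Compound 3 `CCCN(CCC)c1ccc2cc(NC(=O)CCc3ccc(C(F)(F)F)cc3)ccc2n1` gives 490 nM, the highest of the three numbers, reached by a 250-fold higher number from compound 1 to compound 3 (2.39 log units; beyond the scatter) and likewise by a 250-fold higher number from compound 2 to compound 3 (2.39 log units; beyond the scatter). Both measured steps that lead to compound 3 are large and in the same direction, and both consist of dipropylamino entering in place of a methyl-bearing amino group.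

Compound 4 `CC(C)C(=O)NC1CCN(c2ccc3cc(NC(=O)CCc4ccc(C(F)(F)F)cc4)ccc3n2)C1` differs from compound 3 in one place: 3-((isopropylcarbonyl)amino)pyrrolidin-1-yl in place of dipropylamino on an aromatic carbon. The dipropylamino group that came in with the large increases toward compound 3 leaves again, which argues for a step back toward the lower numbers of compound 1 and compound 2. Among the compounds with values here, the entering group has no measured counterpart, so the size of that return is uncertain and the estimate is kept between the extremes. For compound 4 a decrease of a 20-fold lower number from compound 3 to compound 4 (1.29 log units; beyond the scatter) is expected in this assay. The estimated value for compound 4 is 25 nM, with a range from 3 nM to 200 nM.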

Compound 4, half-maximal inhibitory concentration: 1 nM
Beside the measured number, compound 4's estimate is 25-fold (1.40 log units) above it; the whole stated range lies above it.
By their numbers in this assay, from the lowest: compounds 4, 1 and 2 (each within the scatter of the next); then compound 3.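

On the aromatic carbon next to the ring nitrogen, the high number of compound 3 proves specific to dipropylamino in this series: in this assay, 3-((isopropylcarbonyl)amino)pyrrolidin-1-yl in its place gives a 490-fold lower number from compound 3 to compound 4 (2.69 log units; beyond the scatter), even though the entering group has more heavy atoms and adds a ring, a carbonyl and a hydrogen-bond donor. The same group stands level with both open-chain amino groups, with a 2.0-fold lower number from compound 1 to compound 4 (0.30 log units; within the scatter) and a 2.0-fold lower number from compound 2 to compound 4 (0.30 log units; within the scatter), so this position accommodates quite different groups at values within the scatter of one another. The earlier compounds shown here left open whether a methyl on the attached nitrogen was needed for the low numbers; compound 4 has no such methyl, and among the four compounds only compound 3 stands apart.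

No measurement at hand bears on why dipropylamino behaves differently. From the compounds shown here alone, it remains open whether the low number of compound 4 depends on the isopropylcarbonyl part, as unsubstituted pyrrolidin-1-yl or a pyrrolidine carrying a free amine would show, and whether diethylamino would follow compound 3 or the other three compounds.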